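The source may report more compounds than this note shows. Statements on the series, on what has been measured and on what is new or still open speak of the compounds shown alone.

Measured so far in an assay on microsomes for inhibition of acyl-CoA:cholesterol acyltransferase (Oryctolagus cuniculus); a higher number here means a weaker inhibitor, a lower number a stronger inhibitor:
Compound 1, `CC(C)c1ccc(C2(CNC(=O)Nc3c(C(C)C)cccc3C(C)C)CCCC2)cc1`, compound 1 gives 48 nM.
Compound 2, `CC(C)c1cccc(C(C)C)c1NC(=O)NCC1(c2ccccc2C(F)(F)F)CCCC1`, compound 2 gives 18 nM.
Compound 3, `CC(C)c1cccc(C(C)C)c1NC(=O)NCC1(c2cccc([N+](=O)[O-])c2)CCCC1`, compound 3 gives 51 nM.

Compound 3 carries the highest of the three numbers in this assay, but one of the two gaps (a 1.1-fold higher number from compound 1 to compound 3 (0.03 log units; within the scatter)) is within the scatter, while the other (a 2.8-fold higher number from compound 2 to compound 3 (0.45 log units; beyond the scatter)) is a modest step beyond it. Compound 4, `CC(C)c1cccc(C(C)C)c1NC(=O)NCC1(c2ccc(NCCO)cc2)CCCC1`, differs from compound 3 only at the aryl group: 4-((2-hydroxyethyl)amino)phenyl in place of 3-nitrophenyl on a saturated ring carbon. Both measured steps that vary this aryl group are small or within the scatter, and none of them brings in a hydroxyethylamino group, so the direction of this step is uncertain; no change beyond the scatter is expected, a 1.4-fold higher number from compound 3 to compound 4 (0.14 log units; within the scatter). Compound 4 is therefore estimated at 70 nM, within 25 nM to 250 nM.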

Compound 4, half-maximal inhibitory concentration: 25 nM
Compound 4: middle estimate off by 2.8-fold (0.45 log units), on the high side; the range from low to high includes it.
By their numbers in this assay, from the lowest: compounds 2, 4, 1 and 3 (each within the scatter of the next, the first and the last beyond it).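

In this assay, 4-((2-hydroxyethyl)amino)phenyl in place of 3-nitrophenyl gives a 2.0-fold lower number from compound 3 to compound 4 (0.31 log units; beyond the scatter) and so a modest gain, showing that this saturated ring carbon accepts an aryl group with hydrogen-bond donors, which 3-nitrophenyl lacks. The group does not separate from the other aryl groups, with a 1.4-fold higher number from compound 2 to compound 4 (0.14 log units; within the scatter) and a 1.9-fold lower number from compound 1 to compound 4 (0.28 log units; within the scatter) as the remaining comparisons. Nothing shown here explains the gain. Going by these compounds, whether the hydroxyl or the nitrogen of the chain matters stays open. An aryl group with a plain amino group, or a longer hydroxypropylamino chain, would help separate them.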